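Lengthening the phenoxy chain on a bicyclic thiazole acid

The source may hold more compounds than are shown below. What is called first, only, known or untested is meant among the compounds shown, and "the series" means these compounds.

Measured compounds:
Compound 1, `O=C(O)c1csc([C@H]2CC[C@@H]3[C@@H](/C=C/COc4ccccc4)[C@H](O)C[C@@H]3O2)n1`: 700 nM
Compound 2, `O=C(O)c1csc([C@H]2CC[C@@H]3[C@@H](COc4ccccc4)[C@H](O)C[C@@H]3O2)n1`: > 10000 nM

Both compounds were tested in a functional assay on CHO cells for agonist activity at prostaglandin E2 receptor EP1 subtype (Homo sapiens), read by fluorescence and calcium flux; a lower number here means that less compound is needed, a higher number that more compound is needed for the effect. Compound 1 gives 700 nM in this assay. Compound 2, in this assay, gives > 10000 nM, and that figure is a limit of the assay rather than a number. The evidence on this is the limit of > 10000 nM in this assay, at which 1 of the 2 values shown sits, so compound 2 stands at the edge of what this assay can report, while compound 1 stands with a measured value. Since no step between the two is shown, only the two values themselves can be stated.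

Compound 3, `O=C(O)c1csc([C@H]2CC[C@@H]3[C@@H](CCCOc4ccccc4)[C@H](O)C[C@@H]3O2)n1`, has not yet been measured in this assay. It differs from compound 2 by 2-phenoxyethyl in place of phenoxy on a saturated chain carbon bound to a saturated ring carbon. The chain carrying the phenoxy group therefore grows longer in compound 3.

Compound 3 is expected to improve over compound 2, with the step from compound 2 to compound 3 estimated as an at least 5.0-fold lower number from compound 2 to compound 3 (0.69 log units; beyond the scatter). The estimated value for compound 3 in this assay is 2000 nM, with a range from 400 nM to 10000 nM.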

Compound 3, half-maximal effective concentration: 4200 nM
Compound 3: the middle estimate sits 2.1-fold (0.32 log units) below what was measured; the range from low to high includes it.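

On a saturated chain carbon bound to a saturated ring carbon, putting 2-phenoxyethyl in place of phenoxy gives an at least 2.3-fold lower number from compound 2 to compound 3 (0.37 log units; beyond the scatter) in this assay, so a longer chain brings a measurable response even without a double bond. The true size of this step remains unknown, and the printed figure is only a minimum, because compound 2 sits at a limit of the assay rather than at a number: the limit of > 10000 nM in this assay, at which 1 of the 3 values shown sits.

The longer chain does not by itself match the best value shown, since compound 3 gives 4200 nM while compound 1, which carries a double bond in its chain, gives 700 nM.

On these data alone, whether a still longer chain would lower the number further, or whether the gain would fade beyond 2-phenoxyethyl, remains open. Also open, as far as these compounds go, is what the chain oxygen contributes, a question that an all-carbon phenylpropyl chain could address, and whether a chlorine or fluorine on the phenyl ring would shift the number in this assay.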